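From phenyl to 2-carboxyphenyl in compound 1

The source may report more compounds than this note shows. Statements on the series, on what has been measured and on what is new or still open speak of the compounds shown alone.

In a functional assay on SK-OV-3 cells (Homo sapiens) for inhibition, read by CCK-8 assay, with a stated time of 70 h (a lower number here means a stronger inhibitor, a higher number a weaker inhibitor), compound 1 (`c1ccc(COc2ccc(OCCOCCNC3CCCC3)cc2)cc1`) gives 24800 nM, the highest of the three measured numbers and so the weakest inhibitor so far. Compound 2 (`c1ccc(COc2ccc(OCCOCCNC3CCCCC3)cc2)cc1`) gives 7370 nM, and compound 3 (`c1ccc(COc2ccc(OCCOCCNc3cc[nH]c3)cc2)cc1`) gives 11300 nM.

Compound 4 (`O=C(O)c1ccccc1COc1ccc(OCCOCCNC2CCCC2)cc1`) keeps the amine side of compound 1 and has carboxy in place of hydrogen on an aromatic carbon. All measured steps lie at the amine nitrogen: a 3.4-fold lower number from compound 1 to compound 2 (0.53 log units; beyond the scatter), a 2.2-fold lower number from compound 1 to compound 3 (0.34 log units; beyond the scatter) and a 1.5-fold higher number from compound 2 to compound 3 (0.19 log units; within the scatter). Among the compounds with values here, none touches the aromatic ring, and no measured compound carries a carboxy group, so these steps serve only as a rough scale for single changes. In this assay only a small step towards a higher number is expected, one that may stay within the scatter, and its direction is weakly supported. The estimated step is a 1.2-fold higher number from compound 1 to compound 4 (0.08 log units; within the scatter). Compound 4 is estimated at 30000 nM, with an expected range from 9000 nM to 90000 nM.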

Compound 4, half-maximal inhibitory concentration: > 100000 nM
Compound 4 ended at the assay's limit; the forecaster's own chance of this, stated with the estimate: 20%; at least 3.3-fold (0.52 log units) between middle value and limit.
By their numbers in this assay, from the lowest: compounds 2 and 3 (each within the scatter of the next); then compound 1. At a limit, above all of these: compound 4.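

In this assay compound 4 gives > 100000 nM, which is a limit of the assay and not a number. Carboxy on the six-membered aromatic ring of carbon only, ortho to a large group, gives an at least 4.0-fold higher number from compound 1 to compound 4 (0.60 log units; beyond the scatter); this is the first change shown away from the amine nitrogen and the first step shown towards a weaker inhibitor beyond the scatter. The aromatic ring is therefore not a silent place in this series, although the true size of the step stays bounded by one reading: the limit of > 100000 nM in this assay, at which 1 of the 4 values shown sits.

As far as these compounds go, it remains open whether this result belongs to the carboxylic acid itself or to its place, which a methyl ester or a primary amide on the same carbon, or the carboxylic acid on another carbon of that ring, would help to separate. Also open, from the compounds shown here alone, is whether carboxy has the same outcome with the cyclohexyl amine of compound 2 or the 1H-pyrrol-3-yl amine of compound 3.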